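The compounds below may be only part of what the source reports. "The series", "measured", "known", "first", "only" and "open" are said of these compounds alone.

Measured compounds:
compound 1 `O=C(Nc1cccc(-n2cc(-c3ccncc3)c(-c3ccc(Cl)c(O)c3)n2)c1)Nc1cccc(C(F)(F)F)c1`, in a functional assay on HCT-116 cells (Homo sapiens) for inhibition, read by sulforhodamine B assay, with a stated time of 48 h (on this read-out lower numbers stand for higher toxicity in this test and higher numbers for lower toxicity in this test), compound 1 gives a limit, > 32500 nM.
compound 2 `COc1cc(-c2nn(-c3cccc(NC(=O)Nc4cc(C(F)(F)F)cc(C(F)(F)F)c4)c3)cc2-c2ccncc2)ccc1Cl`, in this assay compound 2 gives 4830 nM.
compound 3 `COc1cc(-c2nn(-c3cccc(NC(=O)Nc4cccc(C(F)(F)F)c4)c3)cc2-c2ccncc2)ccc1Cl`, in this assay compound 3 gives a limit, > 50000 nM.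

Compound 3 stands at a limit of this assay, so only a bound is known for it. The step that the two limits leave unreadable from compound 1 to compound 3 cannot be read because the limit of > 32500 nM in this assay, at which 1 of the 3 values shown sits, and the limit of > 50000 nM in this assay, at which 1 of the 3 values shown sits, cap both ends. The step of an at least 10-fold higher number from compound 2 to compound 3 (1.01 log units; beyond the scatter) is large and beyond the scatter; removal of a trifluoromethyl from the aromatic carbon raised the number by that much.

Compound 4 `COc1cc(-c2nn(-c3cccc(NC(=O)c4ccccc4)c3)cc2-c2ccncc2)ccc1Cl` differs from compound 3 by phenyl in place of (3-(trifluoromethyl)phenyl)amino on a carbonyl carbon. This removes the remaining trifluoromethyl together with the amino on that side of the carbonyl. Among the compounds with values here, the only step that bears on it is an at least 10-fold higher number from compound 2 to compound 3 (1.01 log units; beyond the scatter), where losing a trifluoromethyl moved the number up strongly. In this assay compound 4 is therefore expected to stay at or beyond the bound, with the step that the limit leaves unreadable from compound 3 to compound 4 expected to be flat or upward; it is not readable from a limit. The estimate for compound 4 is 70000 nM, with an expected range from 25000 nM to 250000 nM.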

Compound 4, concentration lethal to 50% of the cells: > 100000 nM
Compound 4: a limit, no number; the forecaster's own chance of this, stated with the estimate: 80%; at least 1.4-fold (0.15 log units) between middle value and limit.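

In this assay compound 4 gives a limit, > 100000 nM. Within the data shown here, compound 3 likewise gives only a limit, > 50000 nM, so no step between these two compounds can be read. The compounds shown leave open whether phenyl in place of (3-(trifluoromethyl)phenyl)amino on the carbonyl carbon changes the number at all.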